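Halogenated benzylidene series: cytotoxicity notes, compound 3 to 4

The source may report more compounds than this note shows. Statements on the series, on what has been measured and on what is new or still open speak of the compounds shown alone.

Measured so far:
compound 1, `C=CCn1c(=O)/c(=C\c2cccc(F)c2)[nH]c(=O)/c1=C\c1ccccc1OC`: 2500 nM
compound 2, `C=CCn1c(=O)/c(=C\c2ccc(F)c(Br)c2)[nH]c(=O)/c1=C\c1ccccc1OC`: "not active" (no number reported)
compound 3, `C=CCn1c(=O)/c(=C\c2ccccc2F)[nH]c(=O)/c1=C\c1ccccc1OC`: 5500 nM

All three share one core and differ only in the halogenated phenyl ring. In a functional assay on U-937 cells (Homo sapiens) for cytotoxicity, read by CCK-8 assay, with a stated time of 72 h (on this read-out lower numbers stand for stronger inhibition and higher numbers for weaker inhibition), compound 1 gives 2500 nM, and compound 3 gives 5500 nM, the highest of the two numbers reported; compound 2 is recorded in this assay as "not active" (no number reported), with no number given. Among the measured compounds shown here, the single measured step, a 2.2-fold higher number from compound 1 to compound 3 (0.34 log units; beyond the scatter), is beyond the scatter but modest in size.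

Compound 4, `C=CCn1c(=O)/c(=C\c2cccc(Cl)c2)[nH]c(=O)/c1=C\c1ccccc1OC`, has not been measured in this assay. Its change from compound 3 is 3-chlorophenyl in place of 2-fluorophenyl on a double-bonded chain carbon bound to an aromatic carbon. For the measured compounds named here, this step bears most directly on the move from compound 1 to compound 3, since it returns a halogen to the 3-chlorophenyl pattern after the 2-fluorophenyl of compound 3; the only difference against compound 1 is that chlorine replaces fluorine. Going by the values given here, the sole step available ran in the weakening direction and was modest, so a reversal of similar size is the expectation. Compound 2 gives no number and cannot be weighed.

Compound 4 is therefore expected to come in at 2500 nM, within 1000 nM to 6000 nM. The step from compound 3 is estimated as a 2.2-fold lower number from compound 3 to compound 4 (0.34 log units; beyond the scatter).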

Compound 4, half-maximal inhibitory concentration: 1200 nM
Estimate against measurement, compound 4: 2.1-fold (0.32 log units) above, and the stated range covers the measured number.
By their numbers in this assay, from the lowest: compound 4; then compound 1; then compound 3.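

In this assay, replacing 2-fluorophenyl with 3-chlorophenyl on a double-bonded chain carbon bound to an aromatic carbon gives a 4.6-fold lower number from compound 3 to compound 4 (0.66 log units; beyond the scatter) and leaves compound 4 with the lowest of the three numbers. The earlier compounds shown here showed only a change in where fluorine sits on the phenyl ring, whereas this result shows that the identity of the halogen also counts: chloro in place of fluoro on an aromatic carbon gives a 2.1-fold lower number from compound 1 to compound 4 (0.32 log units; beyond the scatter) and is beyond the scatter, though modest in size. Among the compounds shown here, compound 4 thus differs from each measured neighbour by a readable step, while compound 2, with no number, still allows no step to be read.

Open, from the compounds shown here alone, is whether bromo alone on this phenyl ring would continue the shift seen with chloro, or whether the "not active" entry for compound 2 marks a limit to it. Also open, going by these compounds, is how a nitrile, an amine or a carboxylic acid on this ring would compare with the halogens. No supporting measurement is available to account for either step.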